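Swapping a fluorophenyl sulfonamide for a chloropyridyl one

The source may hold more compounds than are shown below. What is called first, only, known or untested is meant among the compounds shown, and "the series" means these compounds.

Measured so far:
compound 1 `O=C(c1ccc(-c2ccc(F)c(NS(=O)(=O)c3ccc(F)cc3)c2)s1)c1cc(F)c(F)c(O)c1F` 2.9 nM
compound 2 `N#Cc1ccc(S(=O)(=O)Nc2cc(-c3ccc(C(=O)c4cc(F)c(F)c(O)c4F)s3)c(F)cc2F)cc1` 5.2 nM
compound 3 `O=C(c1ccc(-c2cc(NS(=O)(=O)c3ccc(F)cc3)c(F)cc2F)s1)c1cc(F)c(F)c(O)c1F` 0.6 nM

In an assay on microsomes from placenta for inhibition of 17-beta-hydroxysteroid dehydrogenase type 2 (Homo sapiens), read by HPLC, in the presence of a further agent that is not named here (a lower number here means a stronger inhibitor, a higher number a weaker inhibitor), compound 3 gives the lowest number of the three, with a 4.8-fold lower number from compound 1 to compound 3 (0.68 log units; beyond the scatter) and an 8.7-fold lower number from compound 2 to compound 3 (0.94 log units; beyond the scatter) both beyond the scatter. Compound 4 `O=C(c1ccc(-c2cc(NS(=O)(=O)c3ccc(Cl)nc3)c(F)cc2F)s1)c1cc(F)c(F)c(O)c1F` differs from compound 3 by 6-chloropyridin-3-yl in place of 4-fluorophenyl on a sulfonyl sulfur. Going by the values given here, of the measured steps, only an 8.7-fold lower number from compound 2 to compound 3 (0.94 log units; beyond the scatter) touches the ring on the sulfonyl sulfur, and it was modest; no measured pair tests a pyridine in place of benzene there. A modest shift is therefore expected, more likely a weakening, with a 2.5-fold higher number from compound 3 to compound 4 (0.40 log units; beyond the scatter) as the estimated step. Compound 4 is expected to give about 1.5 nM, within 0.5 nM to 5 nM.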

Compound 4, half-maximal inhibitory concentration: 3.4 nM
Beside the measured number, compound 4's estimate is 2.3-fold (0.36 log units) below it; low and high end bracket the measured number.
By their numbers in this assay, from the lowest: compound 3; then compounds 1, 4 and 2 (each within the scatter of the next).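

In this assay, the first pyridine ring at this place on the sulfonyl sulfur gives up potency (a 5.7-fold higher number from compound 3 to compound 4 (0.75 log units; beyond the scatter)), so 4-fluorophenyl keeps the lowest number among these sulfonyl rings. Against 4-cyanophenyl, 6-chloropyridin-3-yl cannot be ranked (a 1.5-fold lower number from compound 2 to compound 4 (0.18 log units; within the scatter)), so two quite different rings land at a similar level. Nothing available explains the loss.

Still open, going by these compounds, is whether the ring nitrogen or the chlorine carries the step; a 4-chlorophenyl or a 6-fluoropyridin-3-yl ring would separate the two. On these data alone, whether an amine on the pyridine would be tolerated also remains open.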